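The source may report more compounds than this note shows. Statements on the series, on what has been measured and on what is new or still open speak of the compounds shown alone.

In a functional assay on A2780 cells (Homo sapiens) for antiproliferative activity, read by sulforhodamine B assay, with a stated time of 48 h (on this read-out higher numbers stand for weaker inhibition of growth and lower numbers for stronger inhibition of growth), compound 1 `CC(C)(C)[Si](C)(C)O[C@@H]1CCCO[C@@H]1/C=C\C(=O)OCc1ccccc1` gives 29000 nM, while compound 2 `COC(=O)/C=C\[C@H]1OCCC[C@H]1O[Si](C)(C)C(C)(C)C` gives 7300 nM, the lower of the two numbers. Compound 3 `C=C[C@H]1OCCC[C@H]1O[Si](C)(C)C(C)(C)C` has not yet been measured. The structural change from compound 2 is vinyl in place of 2-(methoxycarbonyl)ethenyl on a saturated ring carbon. With this change, the ester is lost entirely. Among the measured compounds shown here, only one measured step bears on this: a 4.0-fold lower number from compound 1 to compound 2 (0.60 log units; beyond the scatter), a modest change within the ester itself. For the measured compounds named here, that step shows that altering the ester can shift the number, but no measured compound lacks the ester, so the size of this larger change remains uncertain. A move to a higher number, meaning weaker inhibition of growth, is expected, and the estimated step is a 3.4-fold higher number from compound 2 to compound 3 (0.53 log units; beyond the scatter). The expected value for compound 3 is 25000 nM, with an estimated range from 7000 nM to 100000 nM.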

Compound 3, concentration for 50% growth inhibition: 86000 nM
Compound 3: middle estimate off by 3.4-fold (0.54 log units), on the low side; the measured number falls inside the stated range.
By their numbers in this assay, from the lowest: compound 2; then compound 1; then compound 3.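

In this assay, the change to vinyl is a 12-fold higher number from compound 2 to compound 3 (1.07 log units; beyond the scatter), a larger step than the earlier change within the ester, a 4.0-fold lower number from compound 1 to compound 2 (0.60 log units; beyond the scatter). This shows that removing the ester altogether from this saturated ring carbon, rather than only altering it, goes with much weaker inhibition of growth. Nothing available here accounts for the size of this step.

The change removes the ester's carbonyl and oxygens and shortens the group in one move, so the compounds shown cannot tell which of these matters. A carboxylic acid, an amide or a longer chain with no oxygen at this position would help to separate those two effects.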